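Sulfonamide series: amide variants on the sulfonyl-bearing ring

This account rests on a few compounds, and the source may have more. Where it says the series, first, only, none or still open, it means among the compounds named here.

Measured compounds:
compound 1 `N#Cc1cc(NS(=O)(=O)c2ccc(N)cc2)ccc1Oc1ccc(Cl)c(C(F)(F)F)c1` gives 67%
compound 2 `CC(=O)NCc1ccc(S(=O)(=O)Nc2ccc(Oc3ccc(Cl)c(C(F)(F)F)c3)c(C#N)c2)cc1` gives 80%

In an assay for inhibition of platelet-activating factor acetylhydrolase (Rattus norvegicus), in plasma, with stated times of 30 min and 10 min, tested at 250 nM (on this read-out higher numbers stand for more inhibition at the one concentration tested (going by the name of the read-out) and lower numbers for less inhibition), compound 1 stands lowest of the two numbers shown, and its nearest neighbour is compound 2, which gives 80%. Among the measured compounds shown here, the only measured step is a number 13 percentage points higher from compound 1 to compound 2 (beyond the scatter), a modest gain, from acetamidomethyl in place of amino on an aromatic carbon.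

The step to compound 3 `CC(=O)N(C)c1ccc(S(=O)(=O)Nc2ccc(Oc3ccc(Cl)c(C(F)(F)F)c3)c(C#N)c2)cc1` is acetyl(methyl)amino in place of amino on an aromatic carbon. This change is the only one that bears on the unmeasured compound, and it is related to the measured step in that both replace the amino group with an acetylated nitrogen, though here the acetyl and a methyl sit directly on the ring nitrogen rather than on a methylene. Both changes remove the donor pair of the amino group and carry a carbonyl into the same position. The measured step was beyond the scatter but modest, so a change of similar direction and smaller or equal size is expected here, with real uncertainty whether it clears the scatter at all.

For compound 3 the estimated step is a number 7 percentage points higher from compound 1 to compound 3 (within the scatter), expected on the basis of a number 13 percentage points higher from compound 1 to compound 2 (beyond the scatter). Compound 3 is therefore estimated at 74%, with a range from 58% to 87%.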

Compound 3, a percentage reported as inhibition, at one concentration (the size of the read-out at that concentration, not a potency): 45%
Compound 3: middle estimate off by 29 percentage points, on the high side, outside the stated range (below it).
By their numbers in this assay, from the lowest: compound 3; then compound 1; then compound 2.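

At this aromatic carbon, para to a large group, replacing amino does not push the number in one direction in this assay: acetyl(methyl)amino gives a number 22 percentage points lower from compound 1 to compound 3 (beyond the scatter), the opposite direction to the gain seen with acetamidomethyl. Exchanging the two acetyl-bearing groups gives a number 35 percentage points lower from compound 2 to compound 3 (beyond the scatter), the largest step in this set, so the presence of an acetyl group alone does not set the outcome at this position. Nothing available on these compounds explains the lower number of compound 3.

Acetyl(methyl)amino and acetamidomethyl differ both in the methyl on the nitrogen and in the methylene that links the nitrogen to the ring, and the compounds shown do not separate these two features; the plain acetylamino group on the same carbon would bear directly on that question. From the compounds shown here alone, it also remains open whether the gain seen with acetamidomethyl extends to other groups on a methylene link, such as an aminomethyl group or a longer chain ending in an amide.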